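Three thiocarbonyl anilines that all sit at the assay limit

The source may hold more compounds than are shown below. What is called first, only, known or untested is meant among the compounds shown, and "the series" means these compounds.

Measured compounds, with their values in a functional assay on PBMC cells (Homo sapiens) for inhibition, read by thymidine incorporation, with a stated time of 72 h; a higher number here means a weaker inhibitor, a lower number a stronger inhibitor:
compound 1, `CC1(C)CC(=O)C(C(=S)SCc2ccccc2)=C(Nc2ccc(Cl)cc2Cl)C1` — compound 1 gives > 50 ug/mL, a limit of the assay, not a number.
compound 2, `CC1(C)CC(=O)C(C(=S)SCCO)=C(Nc2ccc(Cl)cc2Cl)C1` — compound 2 gives > 50 ug/mL, again a limit.
compound 3, `CC1(C)CC(=O)C(C(=S)SCc2ccccc2)=C(Nc2ccc(Br)cc2)C1` — compound 3 gives > 50 ug/mL, again a limit.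

Compound 4, `CC1(C)CC(=O)C(C(=S)SCCO)=C(Nc2ccc(Br)cc2)C1`, has not been measured. It differs from compound 3 by hydroxymethyl in place of phenyl on a saturated chain carbon bound to a sulfur. The same change separates compound 1 from compound 2, (hydroxymethyl in place of phenyl on a saturated chain carbon bound to a sulfur), and the place is the same, so this is the same change seen twice. Among the measured compounds shown here, the size it made the first time is a step that the two limits leave unreadable from compound 1 to compound 2. The two cores differ by 4-bromophenyl in place of 2,4-dichlorophenyl on an amine nitrogen, a step of size a step that the two limits leave unreadable from compound 1 to compound 3.

With all three values sitting at the limit of > 50 ug/mL in this assay, at which 3 of the 3 values shown sit, the step from compound 3 to compound 4 is expected to be unreadable in the same way, a step that the limit leaves unreadable from compound 3 to compound 4. Compound 4 is therefore estimated at 65 ug/mL in this assay, most likely reported only as a limit, because compound 2 with the same change sat at the limit of > 50 ug/mL in this assay, at which 3 of the 3 values shown sit.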

Compound 4, half-maximal inhibitory concentration: 8.3 ug/mL
For compound 4 the middle estimate is 7.8-fold (0.89 log units) above the measured one, outside the stated range (below it).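

In this assay, hydroxymethyl in place of phenyl on a saturated chain carbon bound to a sulfur gives an at least 6.0-fold lower number from compound 3 to compound 4 (0.77 log units; beyond the scatter), which shows that this change can matter when the amine nitrogen carries 4-bromophenyl. With the 2-hydroxyethyl chain kept, 4-bromophenyl in place of 2,4-dichlorophenyl gives an at least 6.0-fold lower number from compound 2 to compound 4 (0.77 log units; beyond the scatter), so the result of the chain change is tied here to one amine substituent and cannot simply be assumed for the other. The chain change is sized on one core only, and whether it lowers the number at all on the core of compound 1 stays unknown, because the steps among compounds 1, 2 and 3 cannot be read: the limit of > 50 ug/mL in this assay, at which 3 of the 4 values shown sit.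

The compounds shown leave open whether the step comes from gaining the hydroxyl or from losing the phenyl ring, which a plain ethyl chain, a 2-methoxyethyl chain or a chain ending in an amine or a carboxylic acid could help to separate. Also open, on these data alone, is whether 4-chlorophenyl or 4-fluorophenyl on the amine nitrogen would behave like 4-bromophenyl.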